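This account rests on a few compounds, and the source may have more. Where it says the series, first, only, none or still open, it means among the compounds named here.

Measured in a functional assay on KB cells (Homo sapiens) for antiproliferative activity, read by sulforhodamine B assay, with a stated time of 3 days; a lower number here means that less compound is needed, a higher number that more compound is needed for the effect:
- Compound 1 `CCC1=C(O)c2c(oc(-c3ccccc3)cc2=O)C(CC)(CC)C1=O`: > 236 uM, a limit.
- Compound 2 `CCC1=C(O)c2c(oc(-c3ccc(C(C)C)cc3)cc2=O)C(CC)(CC)C1=O`: 8.13 uM.
- Compound 3 `CCC1=C(O)c2c(oc(-c3ccccc3F)cc2=O)C(CC)(CC)C1=O`: > 56.2 uM, a limit.

Compound 3 therefore stands at a limit, with no number of its own. Compound 4 `CCC1=C(O)c2c(oc(-c3ccc(C)cc3C)cc2=O)C(CC)(CC)C1=O` differs from it as follows: 2,4-dimethylphenyl in place of 2-fluorophenyl on an aromatic carbon.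

Isopropyl in place of hydrogen on an aromatic carbon gave an at least 29-fold lower number from compound 1 to compound 2 (1.46 log units; beyond the scatter). Moving to the 2-fluorophenyl compound gave an at least 6.9-fold higher number from compound 2 to compound 3 (0.83 log units; beyond the scatter). Fluoro in place of hydrogen gave a step that the two limits leave unreadable from compound 1 to compound 3, so that step offers no guidance.

Compound 4 has no isopropyl group, so only part of the gain seen in an at least 29-fold lower number from compound 1 to compound 2 (1.46 log units; beyond the scatter) is expected, in the direction of a lower number in this assay. The expected change is an at least 2.2-fold lower number from compound 3 to compound 4 (0.35 log units; beyond the scatter). For compound 4 the estimate is 25 uM, with an expected range of 8 uM to 80 uM.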

Compound 4, concentration for half-maximal effect: 41.2 uM
Compound 4: the middle estimate sits 1.6-fold (0.22 log units) below what was measured; measured number inside the range.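

On the aromatic carbon next to the ring oxygen, the 2,4-dimethylphenyl group gives a measured number in this assay, and the gain at this position does not require the isopropyl group, with an at least 5.7-fold lower number from compound 1 to compound 4 (0.75 log units; beyond the scatter). The 4-isopropylphenyl group still gives the lower number, with a 5.1-fold higher number from compound 2 to compound 4 (0.70 log units; beyond the scatter). The comparison with 2-fluorophenyl yields only a floor, an at least 1.3-fold lower number from compound 3 to compound 4 (0.13 log units; that floor lies within the scatter), because compound 3 stands at a limit: the limit of > 56.2 uM in this assay, at which 1 of the 4 values shown sits.

On these data alone, it remains open which of the two methyl groups in compound 4 matters. As far as these compounds go, how an amine or a carboxylic acid on this phenyl ring would read also remains open.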